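The source may report more compounds than this note shows. Statements on the series, on what has been measured and on what is new or still open speak of the compounds shown alone.

In a functional assay on SK-OV-3 cells (Homo sapiens) for cytotoxicity, read by spectrophotometry, with a stated time of 72 h (a lower number here means a stronger inhibitor, a higher number a weaker inhibitor), two compounds have been measured so far:

Compound 1 `COc1cc(-n2c(-c3ccc([N+](=O)[O-])cc3)cccc2=O)cc(OC)c1OC` gives 201 nM
Compound 2 `COc1cc(-c2cccc(=O)n2-c2cccc(F)c2)cc(OC)c1OC` gives 340 nM

Within the data shown here, compound 2 stands within the scatter of compound 1, the only other compound measured, so these two values do not separate. Among the measured compounds shown here, compound 3 `COc1cc(-c2cccc(=O)n2-c2ccc(F)cc2)cc(OC)c1OC` has the same atoms as compound 2 joined differently, with 4-fluorophenyl in place of 3-fluorophenyl on an aromatic nitrogen as the only change. For the measured compounds named here, no two measured compounds differ in one place only, so the data offer no direct measure of such a change. Starting from compound 2 at 340 nM no change beyond the scatter is expected in this assay and neither direction is favoured. The expected step is a 1.1-fold lower number from compound 2 to compound 3 (0.05 log units; within the scatter) and it stays within the scatter. Compound 3 is estimated at 300 nM with an expected range from 110 nM to 800 nM when measured.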

Compound 3, half-maximal inhibitory concentration: 9740 nM
Beside the measured number, compound 3's estimate is 32-fold (1.51 log units) below it; the measured number lies above the stated range.
By their numbers in this assay, from the lowest: compounds 1 and 2 (each within the scatter of the next); then compound 3.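

In this assay, the first pair differing in one place shows that this position is highly sensitive: 4-fluorophenyl in place of 3-fluorophenyl on an aromatic nitrogen gives a 29-fold higher number from compound 2 to compound 3 (1.46 log units; beyond the scatter). Among these compounds, the two compounds have the same atoms, so where the fluorine sits on this phenyl ring is enough to move the number well beyond the scatter, something the earlier compounds could not show. Nothing at hand accounts for the size of this step.

On these data alone, it remains open whether the higher number belongs to fluorine alone or would also follow other groups at the same ring position, such as 4-chlorophenyl or 4-methoxyphenyl. As far as these compounds go, how an unsubstituted phenyl or a 2-fluorophenyl on the same nitrogen would compare with this pair also remains open.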